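Removing the aryl group from a quinoline thiosemicarbazone

This account rests on a few compounds, and the source may have more. Where it says the series, first, only, none or still open, it means among the compounds named here.

Measured compounds and their values:
- Compound 1, `COc1ccccc1NC(=S)N/N=C/c1ccc2ccccc2n1`: 91700 nM
- Compound 2, `FC(F)(F)c1ccccc1NC(=S)N/N=C/c1ccc2ccccc2n1`: 13200 nM
- Compound 3, `N#Cc1ccc(NC(=S)N/N=C/c2ccc3ccccc3n2)cc1`: 4660 nM

All three compounds share the same core and differ only in the aryl group attached to the amide-type nitrogen of the thiourea. They were tested in a functional assay on HL-60 cells (Homo sapiens) for antiproliferative activity, read by sulforhodamine B assay, with a stated time of 72 h; on this read-out higher numbers stand for weaker inhibition and lower numbers for stronger inhibition. Compound 3 gives the lowest number of the three in this assay, and its steps to both others lie beyond the scatter, so it is the strongest inhibitor measured here.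

Compound 4, `NC(=S)N/N=C/c1ccc2ccccc2n1`, carries no aryl group at all on that nitrogen. The change from compound 3 is hydrogen in place of 4-cyanophenyl on an amide-type nitrogen. Within the data shown here, two measured steps bear on this position. The exchange a 6.9-fold lower number from compound 1 to compound 2 (0.84 log units; beyond the scatter) and the exchange a 20-fold lower number from compound 1 to compound 3 (1.29 log units; beyond the scatter) both show that the group on this nitrogen moves the number substantially. Neither step removes the aryl ring, so the direction for compound 4 cannot be read directly; the pattern, however, is that the 4-cyanophenyl variant gives the strongest inhibition, and stripping it away is expected to cost potency.

The estimate for compound 4 in this assay is 30000 nM, with a range from 8000 nM to 120000 nM, meaning an expected step of a 6.4-fold higher number from compound 3 to compound 4 (0.81 log units; beyond the scatter).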

Compound 4, half-maximal inhibitory concentration: > 100000 nM
Compound 4: a limit, no number; the forecaster's own chance of this, stated with the estimate: 15%; middle value at least 3.3-fold (0.52 log units) away from the limit.
By their numbers in this assay, from the lowest: compound 3; then compound 2; then compound 1. At a limit, above all of these: compound 4.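

In this assay, compound 4 gives no number, only a limit: the limit of > 100000 nM in this assay, at which 1 of the 4 values shown sits. Even so, the limit supports a reading the earlier compounds could not give, namely an at least 21-fold higher number from compound 3 to compound 4 (1.33 log units; beyond the scatter) on this change. Those compounds only exchanged one aryl group for another, whereas here 4-cyanophenyl leaves and a bare hydrogen takes its place on the amide-type nitrogen, and the inhibition seen with the ring is lost in this comparison. The matching step for the loss of 2-methoxyphenyl (an at least 1.0-fold higher number from compound 1 to compound 4 (0.03 log units; that floor lies within the scatter)) cannot be read, so an aryl group on this nitrogen is shown to matter only for the 4-cyanophenyl case, and whether removing 2-methoxyphenyl changes anything remains unknown.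

The compounds shown leave open whether an aromatic ring is needed on this nitrogen at all, or whether a simple methyl group, a longer alkyl chain or a saturated cyclohexyl ring would keep some of the inhibition. They also leave open how far the result depends on the nitrile, since a phenyl ring bearing an amine or a carboxylic acid in its place would test that directly.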